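Swapping 4-fluorophenyl for 3-bromophenyl

The source may hold more compounds than are shown below. What is called first, only, known or untested is meant among the compounds shown, and "the series" means these compounds.

Of the compounds shown here, two have been measured so far in a functional assay on K562 cells (Homo sapiens) for antiproliferative activity, read by MTT assay; a lower number here means a stronger inhibitor, a higher number a weaker inhibitor. Compound 1 (`COc1cccc(/C(C)=N/NC(=S)NCCCCCC(=O)NO)c1`) gives 1910 nM, and compound 2 (`C/C(=N\NC(=S)NCCCCCC(=O)NO)c1ccc(F)cc1`) gives 1890 nM. These two numbers lie within the scatter of each other, so compound 2 stands level with compound 1 and the pair cannot be ranked.

Compound 3 (`C/C(=N\NC(=S)NCCCCCC(=O)NO)c1cccc(Br)c1`), not yet measured, departs from compound 2 in one place: 3-bromophenyl in place of 4-fluorophenyl on a carbon with a double bond to nitrogen. Put simply, 3-bromophenyl stands in place of 4-fluorophenyl on a carbon with a double bond to nitrogen. Among the measured compounds shown here, the one measured step that bears on this is a 1.0-fold lower number from compound 1 to compound 2 (0.00 log units; within the scatter), an exchange of the ring group on that same carbon, and it stays within the scatter. For the measured compounds named here, a single step is thin evidence, and no compound carrying bromine has been measured yet. On the strength of that step, no change beyond the scatter is expected in this assay, and no direction can be favoured. The expected step is a 1.1-fold lower number from compound 2 to compound 3 (0.05 log units; within the scatter). For compound 3 the estimated value is 1700 nM, with an expected range from 900 nM to 3200 nM.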

Compound 3, half-maximal inhibitory concentration: 1260 nM
Compound 3: the middle estimate sits 1.3-fold (0.13 log units) above what was measured; the measured number falls inside the stated range.
By their numbers in this assay, from the lowest: compounds 3, 2 and 1 (each within the scatter of the next).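

In this assay, the first compound carrying bromine stays level with the fluorinated one, a 1.5-fold lower number from compound 2 to compound 3 (0.18 log units; within the scatter), so this position accepts 3-bromophenyl in place of 4-fluorophenyl without a change that can be told from the scatter. The exchange on the aromatic carbon gives the same picture, a 1.5-fold lower number from compound 1 to compound 3 (0.18 log units; within the scatter), which means bromo and methoxy cannot be ranked there either, and compound 1, compound 2 and compound 3 now form a level set of three differently substituted phenyl groups on the carbon with a double bond to nitrogen. Nothing available explains why these three numbers sit together.

On these data alone, all three groups are substituted phenyl rings of the same size, so it remains open whether this place would stay as flat with a pyridine ring, or with a phenyl ring carrying an amine or a carboxylic acid. The rest of the structure is shared by all three compounds, which leaves unanswered what a longer chain on that same carbon would do in this assay.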